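Swapping One Chloro for Hydrogen

The source may report more compounds than this note shows. Statements on the series, on what has been measured and on what is new or still open speak of the compounds shown alone.

In a physicochemical assay for acid dissociation, compound 2 (`CN(Cc1ccc(Cl)cc1)Cc1ccc(CNc2ccnc3cc(Cl)ccc23)cc1`) gives 7.44 as its reading, and compound 1 (`CN(Cc1ccc(N(C)C)cc1)Cc1cccc(CNc2ccnc3cc(Cl)ccc23)c1`) gives 7.36 as its reading. These two numbers lie within the usual scatter of repeated measurements, so they cannot be told apart, even though the two structures are not closely matched.

Compound 3 (`CN(Cc1ccccc1)Cc1ccc(CNc2ccnc3cc(Cl)ccc23)cc1`) is compound 2 with hydrogen in place of chloro on an aromatic carbon, which turns the 4-chlorobenzyl group into a benzyl group. Among the compounds with values here, no measured pair of compounds shows this change on its own, so the expectation has no direct precedent. A small upward move is expected: the estimated a number 0.16 log units higher from compound 2 to compound 3 (within the scatter) stays within the scatter. For compound 3 the expected value is 7.6 (range 7.3 to 7.9).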

Compound 3, acid dissociation constant: 7.56
Compound 3: the middle estimate sits 0.04 log units above what was measured; measured number inside the range.
By their numbers in this assay, from the lowest: compounds 1, 2 and 3 (each within the scatter of the next).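

In this assay, putting hydrogen in place of the chloro on the 4-chlorobenzyl group gives a number 0.12 log units higher from compound 2 to compound 3 (within the scatter), and this is the only pair shown that differs in one place. At this position on the aromatic ring, para to a large group, the two compounds therefore cannot be told apart, as their readings with chloro and with hydrogen lie within the scatter of each other. No measurement shown bears on why the reading stays within the scatter.

As far as these compounds go, only chloro and hydrogen can be compared at this position, so it remains open whether an amine, a carboxylic acid or a methoxy group there would give a reading beyond the scatter. From the compounds shown here alone, it also remains open whether a longer chain in place of the benzyl group would shift the reading.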